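Removing the trifluoromethyl group: expectation for compound 4

A few compounds are considered here, and "the series" means these few. Any claim that something is new, unique, unknown or untested is made for them only; others in the source may bear on it.

Compound 1 `C=CC(=O)N1C(=O)CC(c2ccc(C(F)(F)F)cc2)Sc2ccccc21` gives 106000 nM in a functional assay on HL-60 cells (Homo sapiens) for cytotoxicity, read by CCK-8 assay, with a stated time of 24 h; a higher number here means a weaker inhibitor, a lower number a stronger inhibitor. Compound 2 `C=CC(=O)N1C(=O)CC(c2ccc(-c3ccccc3)cc2)Sc2ccccc21` gives 118000 nM and compound 3 `C=CC(=O)N1C(=O)CC(c2ccc([N+](=O)[O-])cc2)Sc2ccccc21` gives 107000 nM; all three numbers lie within the scatter of one another, so compound 1 stands level with the rest of the series rather than apart from it. The three steps that connect them, a 1.1-fold higher number from compound 1 to compound 2 (0.05 log units; within the scatter), a 1.0-fold higher number from compound 1 to compound 3 (0.00 log units; within the scatter) and a 1.1-fold lower number from compound 2 to compound 3 (0.04 log units; within the scatter), show that exchanging the group on this aromatic carbon has so far produced nothing beyond the scatter.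

Compound 4 `C=CC(=O)N1C(=O)CC(c2ccccc2)Sc2ccccc21` differs from compound 1 by hydrogen in place of trifluoromethyl on an aromatic carbon. This is a fourth exchange at the same aromatic carbon, and the three measured steps bear directly on it, each within the scatter. Because compound 1 gives 106000 nM and the earlier exchanges moved nothing, the expected step of a 1.0-fold higher number from compound 1 to compound 4 (0.02 log units; within the scatter) is none beyond the scatter. Compound 4 is therefore estimated at 110000 nM in this assay, with a range from 60000 nM to 200000 nM. Whether a bare hydrogen behaves like the groups tried so far is not shown by these data.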

Compound 4, half-maximal inhibitory concentration: 97400 nM
Compound 4: middle estimate off by 1.1-fold (0.05 log units), on the high side, within the range that was stated.
By their numbers in this assay, from the lowest: compounds 4, 1, 3 and 2 (each within the scatter of the next).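

In this assay the steps with hydrogen on this aromatic carbon are a 1.1-fold lower number from compound 1 to compound 4 (0.04 log units; within the scatter) and a 1.1-fold lower number from compound 3 to compound 4 (0.04 log units; within the scatter) and a 1.2-fold lower number from compound 2 to compound 4 (0.08 log units; within the scatter) in the series. Going by these compounds alone, the earlier compounds showed only that one group could replace another here; compound 4 shows that, on this aromatic carbon para to a large group, no substituent is needed to stay within the scatter of compounds 1, 2 and 3, so all four compounds read as one level. No evidence is available that bears on this flat reading.

Left open is whether an amine or a carboxylic acid at this aromatic carbon would give a step beyond the scatter. Also open, from the compounds shown here alone, is whether any change elsewhere on the shared core, such as a saturated propanoyl group in place of the acryloyl group, would move the number.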